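The source may hold more compounds than are shown below. What is called first, only, known or untested is meant among the compounds shown, and "the series" means these compounds.

Going by the values given here, compound 1 `CCCCc1c(Cl)cc(N/C=N/OCC)cc1Cl` is one of two compounds so far measured in a physicochemical assay for lipophilicity, measured as octanol-water partition (on this read-out higher numbers stand for higher lipophilicity and lower numbers for lower lipophilicity), and in that read-out compound 1 gives 5.6. Among the compounds with values here, its single measured partner is compound 2 `CCO/N=C/Nc1cc(Cl)c(OCC(C)C)c(Cl)c1`, which in this assay gives 5. The two differ by isobutoxy in place of butyl on an aromatic carbon, and compound 1 stands as the higher of the two numbers. Compound 3 `CCO/N=C/Nc1cc(Cl)c(OCCCl)c(Cl)c1` has not yet been measured. Compared with compound 1 it shows (2-chloroethoxy in place of butyl on an aromatic carbon). Within the data shown here, only one measured step bears on this change, a number 0.60 log units lower from compound 1 to compound 2 (beyond the scatter), and there, as here, butyl on an aromatic carbon gives way to a group that contains oxygen. A drop of similar size is therefore expected in this assay, and compound 3 is expected at 4.8, between 4.3 and 5.3. The expected step is a number 0.80 log units lower from compound 1 to compound 3 (beyond the scatter).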

Compound 3, partition coefficient: 4
Beside the measured number, compound 3's estimate is 0.80 log units above it; the whole stated range lies above it.
By their numbers in this assay, from the lowest: compound 3; then compound 2; then compound 1.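

In this assay, the position para to a group of 6 heavy atoms proves more sensitive than the earlier pair could show: 2-chloroethoxy in place of butyl gives a number 1.60 log units lower from compound 1 to compound 3 (beyond the scatter). Groups joined through oxygen at this position also differ widely among themselves, since chloromethyl in place of isopropyl gives a number 1.00 log units lower from compound 2 to compound 3 (beyond the scatter), so the read-out depends on the end of the chain as well as on the oxygen. Nothing at hand gives a cause for either step.

Still open, from the compounds shown here alone, is whether the chlorine or the smaller carbon portion accounts for the second step, as that change alters both at once. An unsubstituted ethoxy group would separate the two, while a methoxy or an amine at the chain end would test how far the trend extends.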